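This account rests on a few compounds, and the source may have more. Where it says the series, first, only, none or still open, it means among the compounds named here.

Measured in a functional assay on M21 cells (Homo sapiens) for antiproliferative activity, read by sulforhodamine B assay, with a stated time of 48 h; a lower number here means a stronger inhibitor, a higher number a weaker inhibitor:
compound 1 `CC(C)c1ccccc1OS(=O)(=O)c1cccc(NC(=O)CCl)c1` gives 3900 nM
compound 2 `CC(C)c1ccccc1OS(=O)(=O)c1cccc(NC(=O)CCCl)c1` reaches only a limit of the assay, > 40000 nM
compound 3 `CC(C)c1ccccc1OS(=O)(=O)c1ccc(NC(=O)CCCl)cc1` gives 14000 nM

Compound 1 and compound 3 differ in more than one place; the difference between their two cores is not broken down here. Compound 3 stands highest of the two numbers, with compound 1 the nearer value. The step of an at least 10-fold higher number from compound 1 to compound 2 (1.01 log units; beyond the scatter) is the change chloromethyl in place of chloro on a saturated chain carbon bound to a carbonyl carbon and runs into the limit (the limit of > 40000 nM in this assay, at which 1 of the 3 values shown sits). Compound 4 `CC(C)c1ccccc1OS(=O)(=O)c1ccc(NC(=O)CCCCl)cc1` is not yet measured; it differs from compound 3 by chloromethyl in place of chloro on a saturated chain carbon, two bonds along the chain from a carbonyl carbon. The place is not the same: in compound 2 the chloromethyl sits on a saturated chain carbon bound to a carbonyl carbon, in compound 4 on one two bonds along the chain from a carbonyl carbon, so this is the same kind of change, not the same. In this assay the step of a 3.6-fold higher number from compound 3 to compound 4 (0.55 log units; beyond the scatter) is expected to weaken the compound in the same direction, resting on an at least 10-fold higher number from compound 1 to compound 2 (1.01 log units; beyond the scatter) and on compound 3 starting from 14000 nM. Compound 4 is therefore estimated at 50000 nM, between 15000 nM and 200000 nM, and is expected most likely to return only a limit.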

Compound 4, half-maximal inhibitory concentration: 5100 nM
Beside the measured number, compound 4's estimate is 9.8-fold (0.99 log units) above it; the whole stated range lies above it.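

In this assay the step of a 2.7-fold lower number from compound 3 to compound 4 (0.44 log units; beyond the scatter) runs opposite to an at least 10-fold higher number from compound 1 to compound 2 (1.01 log units; beyond the scatter), so the effect of this change on the core of compound 1 does not carry over to the core of compound 3: the same change on two cores in this assay, an at least 10-fold higher number (1.01 log units; beyond the scatter) from compound 1 to compound 2 and a 2.7-fold lower number (0.44 log units; beyond the scatter) from compound 3 to compound 4, at least 28-fold (1.44 log units) apart, beyond the scatter of two such steps The value of compound 2, > 40000 nM, is a limit of the assay and not a number: the limit of > 40000 nM in this assay, at which 1 of the 4 values shown sits. With one pair per core and the change at a different place on the chain in each pair, these data do not separate the role of the core from that of the chain place, and they give no rule for any further core.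

Going by these compounds, the chain of compound 4 on the core of compound 1 remains open, which would test the chain place on a single core. Also open, on these data alone, is how a longer chain, or an amine in place of the chloro group, would read in this assay.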